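Cytotoxicity limits across two regioisomeric aminopyrazine amide cores

A few compounds are considered here, and "the series" means these few. Any claim that something is new, unique, unknown or untested is made for them only; others in the source may bear on it.

Measured so far:
compound 1 `CCCCCCCNc1cnc(C(=O)NCc2ccccc2)cn1` — >= 100000 nM in an ADME assay on Vero cells (Chlorocebus sabaeus) for cytotoxicity, read by microscopy, with a stated time of 6 days (a higher number here means that more compound is tolerated, a lower number that less compound is tolerated), a limit
compound 2 `CCCCCCNc1cnc(C(=O)NCc2ccccc2)cn1` — >= 100000 nM in this assay, a limit
compound 3 `CCCCCCNc1nccnc1C(=O)NCc1ccccc1` — > 100000 nM in this assay, a limit

All three values are limits of this assay, not numbers. Compound 1 and compound 2 share one core and differ by methyl in place of hydrogen on a saturated chain carbon, six bonds along the chain from a nitrogen on an aromatic ring. The step that the two limits leave unreadable from compound 2 to compound 1 cannot be read, because both ends sit at the limit of >= 100000 nM in this assay, at which 2 of the 3 values shown sit. Compound 3 carries a different core; the difference between the two cores is not broken down here, and compound 3 alone sits at the limit of > 100000 nM in this assay, at which 1 of the 3 values shown sits.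

Compound 4 `CCCCCCCNc1nccnc1C(=O)NCc1ccccc1` has not yet been measured. It differs from compound 3 by methyl in place of hydrogen on a saturated chain carbon, six bonds along the chain from a nitrogen on an aromatic ring, the same kind of change as that from compound 2 to compound 1, with the place line worded the same in both. Since no tolerance below the limit was seen for compound 1, compound 2 or compound 3, the step from compound 3 to compound 4 is expected to be a number no higher from compound 3 to compound 4 (the limit leaves the size open), which is no more than the unreadable step already seen. Compound 4 is therefore expected to give about 100000 nM, most likely again only a limit in this assay.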

Compound 4, minimum cytotoxic concentration: > 100000 nM
Compound 4: no number, only a limit; the forecaster's own chance of this, stated with the estimate: 90%; the middle value lies on the limit itself.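

Compound 3 and compound 4 each give only a limit in this assay, so the step between them cannot be read: the limit of > 100000 nM in this assay, at which 2 of the 4 values shown sit.

The compounds shown leave open what tolerated concentration any of the four would reach as a number, and whether the methyl change or the difference between the two cores alters tolerance at all.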